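Taking the hydroxy off compound 2

The compounds below may be only part of what the source reports. "The series", "measured", "known", "first", "only" and "open" are said of these compounds alone.

In a functional assay on A2780 cells (Homo sapiens) for cytotoxicity, read by MTT assay, with a stated time of 24 h (on this read-out higher numbers stand for weaker inhibition and lower numbers for stronger inhibition), compound 1 (`CCCCC[C@H](CCC[C@@H]1CC=CC(=O)O1)OC`) gives 14400 nM. Compound 2 (`CCCCC[C@H](C[C@@H](O)C[C@H]1CC=CC(=O)O1)OC`) gives 28900 nM, and compound 3 (`CCCCC[C@H](C[C@@H](O)C[C@@H]1CC=CC(=O)O1)OC`) gives 54500 nM. Compound 2 thus lies within the scatter of both other compounds, even though compound 1 and compound 3 stand apart by more than the scatter.

Compound 4 (`CCCCC[C@H](CCC[C@H]1CC=CC(=O)O1)OC`) has not yet been measured. It departs from compound 2 by hydrogen in place of hydroxy on a saturated chain carbon bound to two saturated chain carbons, which puts hydrogen in place of hydroxy on a saturated chain carbon bound to two saturated chain carbons.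

For the measured compounds named here, two measured steps bear on this change. The same exchange, run in the opposite direction, appears as a 3.8-fold higher number from compound 1 to compound 3 (0.58 log units; beyond the scatter), a modest step. The other step, a 1.9-fold higher number from compound 2 to compound 3 (0.28 log units; within the scatter), stays within the scatter, and it rests on (the fact that compounds 2 and 3 differ only in the configuration as drawn). The hydroxy step can therefore reasonably be carried over to compound 2, though it comes from a single pair. A modest move towards a lower number is expected in this assay, somewhat smaller than the measured one. The expected change is a 2.9-fold lower number from compound 2 to compound 4 (0.46 log units; beyond the scatter). For compound 4 the estimated value is 10000 nM, with an expected range from 4500 nM to 21000 nM.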

Compound 4, half-maximal inhibitory concentration: 17100 nM
The estimate for compound 4 lay 1.7-fold (0.23 log units) below the measured number; measured number inside the range.
By their numbers in this assay, from the lowest: compounds 1, 4, 2 and 3 (each within the scatter of the next, the first and the last beyond it).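

Compound 4 gives the exchange a reading on a second core: in this assay, putting hydrogen in place of hydroxy on a saturated chain carbon bound to two saturated chain carbons gives a 1.7-fold lower number from compound 2 to compound 4 (0.23 log units; within the scatter). The change therefore cannot be told from scatter on this core alone, whereas it could on the core of compound 1, yet the two readings do not disagree with each other: the same change on two cores in this assay, a 3.8-fold higher number (0.58 log units; beyond the scatter) from compound 1 to compound 3 and a 1.7-fold higher number (0.23 log units; within the scatter) from compound 4 to compound 2, 2.2-fold (0.35 log units) apart, within the scatter of two such steps. The new pair also tests the stereocentre at the saturated ring carbon without the hydroxy, giving a 1.2-fold higher number from compound 1 to compound 4 (0.07 log units; within the scatter), so that inversion at this centre stays within the scatter here, as it does with the hydroxy present in a 1.9-fold higher number from compound 2 to compound 3 (0.28 log units; within the scatter), and the comparison is a clean one: the fact that compounds 1 and 4 differ only in the configuration as drawn.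

What the compounds shown leave open is whether an amine or a ketone carbonyl on that same chain carbon would move the number beyond the scatter in either direction. They also leave open how the opposite drawn configuration at the hydroxy-bearing carbon would read, since compounds 2 and 3 share the same one.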